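A few compounds are considered here, and "the series" means these few. Any claim that something is new, unique, unknown or untested is made for them only; others in the source may bear on it.

Compound 1 `COc1cccc(/C=C/c2ccc(S(N)(=O)=O)cc2)c1`: 3810 nM
Compound 2 `NS(=O)(=O)c1ccc(/C=C/c2ccc(F)cc2)cc1`: 42300 nM

Both values come from a functional assay on RPMI-8226 cells (Homo sapiens) for inhibition; a lower number here means a stronger inhibitor of growth, a higher number a weaker inhibitor of growth. Of the two, compound 2 has the higher number and so is the weaker inhibitor of growth, and its gap to compound 1 lies beyond the usual scatter. Compound 3 `CN(C)c1ccc(/C=C/c2ccc(S(N)(=O)=O)cc2)cc1` has not yet been measured. It carries dimethylamino in place of fluoro on an aromatic carbon, para to a large group: dimethylamino in place of fluoro on an aromatic carbon. Within the data shown here, no measured pair isolates a change of this kind, so the evidence is thin. A step towards a lower number, beyond the scatter, is nevertheless expected. Among the measured compounds shown here, the only guide is that compound 1, which has no fluoro, stands at 3810 nM. The expected change is an 11-fold lower number from compound 2 to compound 3 (1.02 log units; beyond the scatter). For compound 3 the estimated value is 4000 nM, with an expected range of 600 nM to 25000 nM.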

Compound 3, concentration for 50% growth inhibition: 11600 nM
Compound 3: middle estimate off by 2.9-fold (0.46 log units), on the low side, within the range that was stated.
By their numbers in this assay, from the lowest: compound 1; then compound 3; then compound 2.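

Among these compounds, measured in this assay, this is the first pair that isolates a single change on the shared core: placing dimethylamino in place of fluoro on an aromatic carbon, para to a large group, gives a 3.6-fold lower number from compound 2 to compound 3 (0.56 log units; beyond the scatter), a modest step that lies beyond the usual scatter. It shows that the number responds to the group carried at this position, at least for these two groups. No available measurement bears on the reason for this step.

From the compounds shown here alone, whether a plain amino group or a smaller methylamino group at this position would give a step of similar size remains open. Going by these compounds, it is also open whether a carboxylic acid or a longer chain of carbon atoms there would move the number in the same direction or the opposite one.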